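A Smaller Thiophene Ring on the Carbonyl Carbon

This account rests on a few compounds, and the source may have more. Where it says the series, first, only, none or still open, it means among the compounds named here.

Compound 1 `COc1ccc(C(=O)/C=C/c2nc3ccccc3cc2-c2ccc(OC)cc2)cc1`: > 10000 nM, a limit of the assay rather than a number.
Compound 2 `COc1ccc(-c2cc3ccccc3nc2/C=C/C(=O)c2ccc(OC)c(OC)c2)cc1`: 7240 nM.
Compound 3 `COc1ccc(-c2cc3ccccc3nc2/C=C/C(=O)c2ccc(Br)s2)cc1`: 9380 nM.

Among the measured compounds shown here, in a functional assay on H184B5F5/M10 cells (Homo sapiens) for antiproliferative activity, read by XTT assay, with a stated time of 72 h (a higher number here means a weaker inhibitor, a lower number a stronger inhibitor), compound 3 gives 9380 nM, the higher of the two numbers known; compound 2 sits nearest, and the two are within the scatter of each other. For compound 1 the value is a limit only, so it cannot be ranked against them.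

Compound 4 `COc1ccc(-c2cc3ccccc3nc2/C=C/C(=O)c2ccsc2)cc1` arises from compound 3 by thiophen-3-yl in place of 5-bromothiophen-2-yl on a carbonyl carbon. Two measured steps also swap the group on the carbonyl carbon. The step of a 1.3-fold higher number from compound 2 to compound 3 (0.11 log units; within the scatter) stays within the scatter, and the step of an at least 1.0-fold lower number from compound 1 to compound 3 (0.02 log units; that floor lies within the scatter) rests on a limit whose floor also lies within the scatter. Neither suggests that exchanging one five-membered aromatic ring for another at this position moves the number far.

Compound 4 is therefore expected to land close to compound 3, with the step of a 1.0-fold lower number from compound 3 to compound 4 (0.02 log units; within the scatter) staying within the scatter. The estimate for compound 4 in this assay is 9000 nM, expected to fall between 4000 nM and 20000 nM.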

Compound 4, half-maximal inhibitory concentration: 6390 nM
Compound 4: the middle estimate sits 1.4-fold (0.15 log units) above what was measured; low and high end bracket the measured number.
By their numbers in this assay, from the lowest: compounds 4, 2 and 3 (each within the scatter of the next). At a limit, above all of these: compound 1.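

In this assay taking away the bromine and shifting the ring's point of attachment together gives a 1.5-fold lower number from compound 3 to compound 4 (0.17 log units; within the scatter) and shows that this position needs no bromine to give a number of this size. Set against the larger 3,4-dimethoxyphenyl group, the bare thiophen-3-yl gives a 1.1-fold lower number from compound 2 to compound 4 (0.05 log units; within the scatter) and so cannot be told apart from it here, although it has no methoxy groups at all. Compound 1 carries a limit rather than a number, which makes an at least 1.5-fold lower number from compound 1 to compound 4 (0.19 log units; that floor lies within the scatter) a floor only: the limit of > 10000 nM in this assay, at which 1 of the 4 values shown sits.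

Compound 3 and compound 4 differ in both the bromine and the point of attachment, and the shared step cannot separate the two. Going by these compounds, whether an amine or a carboxylic acid on the thiophene ring would move the number beyond the scatter also stays open.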